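The source may hold more compounds than are shown below. What is called first, only, known or untested is meant among the compounds shown, and "the series" means these compounds.

Compound 1 `CN(C)c1ccc(Nc2c(NCCCCCC(=O)NO)c(=O)c2=O)cc1` carries a long saturated chain that ends in a hydroxamic acid. In an ADME assay on cells (Hepatocyte, Homo sapiens) for pharmacokinetics, read by LC-MS, with a stated time of 90 min, tested at 1 uM (a lower number here means slower removal, a higher number faster removal of the compound), compound 1 gives only a limit of the assay, < 5 uL/min. Compound 3 `C[C@@H](CCCCC(=O)NO)Nc1c(Nc2ccc(N(C)C)cc2)c(=O)c1=O` differs from it by methyl in place of hydrogen on a saturated chain carbon bound to a nitrogen on an aromatic ring and a saturated chain carbon; in this assay compound 3 gives 3.6 uL/min. The step that the limit leaves unreadable from compound 1 to compound 3 cannot be sized because of the limit of < 5 uL/min in this assay, at which 1 of the 3 values shown sits. Compound 2 `CC(CCCCC(=O)NO)Nc1c(Nc2ccc(C(F)(F)F)cc2)c(=O)c1=O` shares the core, though how its core differs from that of compound 1 is not broken down here; in this assay compound 2 gives 21 uL/min, the highest of the two numbers. Compound 4 `CC(C)(CCCCC(=O)NO)Nc1c(Nc2ccc(C(F)(F)F)cc2)c(=O)c1=O` carries the same kind of change as compound 3, namely (methyl in place of hydrogen on a saturated chain carbon bound to a nitrogen on an aromatic ring and two saturated chain carbons), the place now bound to two saturated chain carbons rather than one. With the earlier step unreadable, the step is expected to be a 1.2-fold lower number from compound 2 to compound 4 (0.07 log units; within the scatter), resting on compound 2 at 21 uL/min. Compound 4 is estimated to give 18 uL/min.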

Compound 4, intrinsic clearance in a liver preparation (reported as CLH), per the amount of preparation that the assay uses: 29 uL/min
The estimate for compound 4 lay 1.6-fold (0.21 log units) below the measured number; low and high end bracket the measured number.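

On the core of compound 2, methyl in place of hydrogen gives in this assay a 1.4-fold higher number from compound 2 to compound 4 (0.14 log units; within the scatter) and so leaves no change that can be told from the usual scatter. This holds for one pair on one core and does not show that the change behaves alike on another core. Among the compounds shown here, compound 1 gives only a limit, so its step to compound 3 cannot be read and no two steps can be set side by side: (the limit of < 5 uL/min in this assay, at which 1 of the 4 values shown sits).

The compounds shown leave open how an amine or a carboxylic acid would compare with methyl on that saturated chain carbon. They also leave open whether a longer chain would give a different step.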